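Swapping the acid-bearing arm for a hydroxyethyl group

The source may hold more compounds than are shown below. What is called first, only, known or untested is meant among the compounds shown, and "the series" means these compounds.

Of the compounds shown here, three sharing one core have been measured. Compound 1 `COC(=O)c1c(F)cccc1-c1ccc(CCc2ncc(CC(C)(C)C)n2CCO)cc1` gives 21 nM in an assay on cells for agonist activity at Bombesin receptor subtype-3 (Homo sapiens), read by HTRF and inositol phosphate accumulation, with a stated time of 1 h; on this read-out lower numbers stand for an effect already at smaller amounts and higher numbers for an effect only at larger amounts of compound. Compound 2 `CC(C)(C)Cc1cnc(CCc2ccc(-c3cccc(F)c3C(=O)O)cc2)n1CCC(=O)O` gives 11 nM, and compound 3 `CC(C)(C)Cc1cnc(CCc2ccc(-c3cccc(F)c3C(=O)O)cc2)n1Cc1ccc(C(=O)O)cc1` gives 12 nM. Compound 3 therefore stands second highest of the three numbers, with compound 2 nearest and compound 1 furthest, both gaps lying within the scatter.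

The next compound, compound 4 `CC(C)(C)Cc1cnc(CCc2ccc(-c3cccc(F)c3C(=O)O)cc2)n1CCO`, arises from compound 3 by a single change: hydroxymethyl in place of 4-carboxyphenyl on a saturated chain carbon bound to an aromatic nitrogen. The acid-bearing arm on the ring nitrogen is replaced by a short chain ending in an alcohol, while the acid on the biaryl part stays.

Within the data shown here, one measured step bears on this. The step of a 1.1-fold higher number from compound 2 to compound 3 (0.04 log units; within the scatter) changed only the arm on the same nitrogen and left the number essentially unchanged. Compound 1 already carries the hydroxyethyl arm that enters here, though with a methyl ester instead of the free acid, and its value sits within the scatter of compound 3. Taken together these points suggest the arm on the nitrogen matters little here, so a step of a 1.3-fold higher number from compound 3 to compound 4 (0.10 log units; within the scatter) is expected for compound 4, that is none beyond the scatter. Compound 4 is estimated at 15 nM, with a range from 6 nM to 40 nM.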

Compound 4, half-maximal effective concentration: 3 nM
The estimate for compound 4 lay 5.0-fold (0.70 log units) above the measured number; the whole stated range lies above it.
By their numbers in this assay, from the lowest: compound 4; then compounds 2, 3 and 1 (each within the scatter of the next).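

In this assay, the arm on the aromatic nitrogen proves to matter after all: exchanging either acid-bearing arm for 2-hydroxyethyl gives a 4.0-fold lower number from compound 3 to compound 4 (0.60 log units; beyond the scatter) and also a 3.7-fold lower number from compound 2 to compound 4 (0.56 log units; beyond the scatter) for the closely related carboxymethyl change at the chain end. The two acid-bearing arms alone had hidden this, since a 1.1-fold higher number from compound 2 to compound 3 (0.04 log units; within the scatter) showed only that they could not be told apart. Compound 1 adds a second point, that with the hydroxyethyl arm held fixed, the free carboxylic acid on the far side of the molecule counts as well, as removing the methyl of the ester gives a 7.0-fold lower number from compound 1 to compound 4 (0.85 log units; beyond the scatter) and no measurement shown gives a reason for any of these steps.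

Going by these compounds, it remains open whether the gain comes from the alcohol itself or simply from the arm ending without a carboxylic acid, which a methyl ether, an amine or a longer chain ending in an alcohol at this place could help separate. Also open, on these data alone, is whether 3-hydroxypropyl would keep the low number of compound 4 3 nM or lose it.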